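The compounds below may be only part of what the source reports. "The series", "measured", "known", "first", "only" and "open" are said of these compounds alone.

Measured in an ADME assay on MRC5 cells (Homo sapiens) for cytotoxicity, read by fluorescence and resazurin assay, with a stated time of 3 days; on this read-out higher numbers stand for weaker inhibition and lower numbers for stronger inhibition:
Compound 1 `Cc1cn(C2CCN(Cc3cccc(Oc4ccc(Cl)cc4)c3)CC2)c(=O)[nH]c1=O`: 25100 nM
Compound 2 `Cc1cn(C2CCN(Cc3cccc(Oc4ccc(Cl)c(Cl)c4)c3)CC2)c(=O)[nH]c1=O`: 6100 nM

Of these two, compound 2 holds the lower number, 6100 nM. Compound 3 (`Cc1cn(C2CCN(Cc3cccc(Oc4cccc(OC(F)(F)F)c4)c3)CC2)c(=O)[nH]c1=O`) has not yet been measured. It keeps the rest of compound 2 and exchanges one group on an oxygen on an aromatic ring: 3-(trifluoromethoxy)phenyl in place of 3,4-dichlorophenyl on an oxygen on an aromatic ring. In words, this is 3-(trifluoromethoxy)phenyl in place of 3,4-dichlorophenyl.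

Within the data shown here, only one measured step bears on this change, and only loosely. It is a 4.1-fold lower number from compound 1 to compound 2 (0.61 log units; beyond the scatter), a modest step for chloro in place of hydrogen on an aromatic carbon. Among the measured compounds shown here, compound 3 carries no chloro, and no measured compound carries its new group, so two compounds offer no firm rule. A small move toward a higher number, meaning weaker inhibition, therefore seems the most likely outcome, though no change beyond the scatter remains possible. The expected size is a 1.8-fold higher number from compound 2 to compound 3 (0.26 log units; within the scatter). For compound 3 the estimated value in this assay is 11000 nM, with an expected range from 4000 nM to 28000 nM.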

Compound 3, half-maximal inhibitory concentration: 5260 nM
For compound 3 the middle estimate is 2.1-fold (0.32 log units) above the measured one; the range from low to high includes it.
By their numbers in this assay, from the lowest: compounds 3 and 2 (each within the scatter of the next); then compound 1.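

In this assay the exchange of 3,4-dichlorophenyl for 3-(trifluoromethoxy)phenyl on the oxygen gives a 1.2-fold lower number from compound 2 to compound 3 (0.06 log units; within the scatter) and so the two groups cannot be told apart on this read-out. Set against the 4-chlorophenyl group, the new group gives a 4.8-fold lower number from compound 1 to compound 3 (0.68 log units; beyond the scatter) and this points the same way as the earlier step, a 4.1-fold lower number from compound 1 to compound 2 (0.61 log units; beyond the scatter) where a second chloro was added. Chlorine on this ring is therefore not required for a number in this lower range: a group with no chlorine, more heavy atoms and one hydrogen-bond acceptor lands there too, at least among these three compounds.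

No measurement at hand explains why these groups give these numbers. On these data alone, whether a methoxy group, an amine or a carboxylic acid on this same phenyl ring would keep the number close to those of compound 2 and compound 3, or return it toward that of compound 1, remains open, and so does whether any group here could separate cell toxicity from the shared core.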